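Does one fluorine repeat its effect on a second core?

The compounds below may be only part of what the source reports. "The series", "measured", "known", "first", "only" and "open" are said of these compounds alone.

Compound 1, `COc1ccc(N(C)c2ccnc(Cl)n2)cc1`, and compound 2, `COc1ccc(N(C)c2ccnc(Cl)n2)cc1F`, were tested in a functional assay on MDA-MB-231 cells (Homo sapiens) for antiproliferative activity, read by MTT assay, with a stated time of 48 h; a higher number here means a weaker inhibitor, a lower number a stronger inhibitor. Compound 1 gives 2820 nM, while compound 2 gives 1280 nM. The change between them is fluoro in place of hydrogen on an aromatic carbon, and it brought a 2.2-fold lower number from compound 1 to compound 2 (0.34 log units; beyond the scatter).

Compound 3, `COc1ccc(N(C)c2cc(C)nc(C)n2)cc1`, carries a different core; how its core differs from that of compound 1 is not broken down here. In this assay compound 3 gives 3650 nM, which lies within the usual scatter of the number for compound 1.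

Compound 4, `COc1ccc(N(C)c2cc(C)nc(C)n2)cc1F`, has not yet been measured. It differs from compound 3 by fluoro in place of hydrogen on an aromatic carbon. The surroundings of the place are described a little differently, meta to a large group rather than meta to a group of 9 heavy atoms, so this is the same kind of change as that from compound 1 to compound 2, not the same change.

If this fluorine acts on the core of compound 3 as it did on the core of compound 1, the expected step is a 2.1-fold lower number from compound 3 to compound 4 (0.33 log units; beyond the scatter), resting on a 2.2-fold lower number from compound 1 to compound 2 (0.34 log units; beyond the scatter). On that basis compound 4 is estimated to give 1700 nM in this assay, with a likely range from 800 nM to 3600 nM.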

Compound 4, half-maximal inhibitory concentration: 2790 nM
Estimate against measurement, compound 4: 1.6-fold (0.22 log units) below; the measured number falls inside the stated range.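

In this assay, the fluorine on the core of compound 3 gives a 1.3-fold lower number from compound 3 to compound 4 (0.12 log units; within the scatter), so on this core alone the step cannot be told apart from the ordinary spread of repeated measurements. Set beside the step on the first core, this result does not stand apart from it: the same change on two cores in this assay, a 2.2-fold lower number (0.34 log units; beyond the scatter) from compound 1 to compound 2 and a 1.3-fold lower number (0.12 log units; within the scatter) from compound 3 to compound 4, 1.7-fold (0.23 log units) apart, within the scatter of two such steps. The change can therefore be carried to the second core without any sign that its effect differs there, but this does not show that the fluorine gives a real gain on that core, that the two steps are truly equal, or that the same would hold on any further core.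

Fluoro is the only group shown entering this place, ortho to a methoxy group, so it remains open how an amine, a hydroxyl group or a nitrile would behave there. Going by these compounds, it also remains open whether any of these would give a step on both cores that lies clearly beyond the scatter.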